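Chloro-to-hydroxy exchange in three inactive purine-like nucleoside analogues

The compounds below may be only part of what the source reports. "The series", "measured", "known", "first", "only" and "open" are said of these compounds alone.

Compound 1 `Oc1ncnc2c1ncn2C[C@@H]1C[C@H](O)c2ccccc21` and compound 2 `O[C@H]1C[C@@H](Cn2cnc3c(Cl)ncnc32)c2ccccc21` share a core, while compound 3 `Nc1nc(Cl)c2ncn([C@H]3CCCC[C@H]3CO)c2n1` carries a different one; the difference between the two cores is not broken down here. In an ADME assay on L1210/0 cells (Mus musculus) for cytotoxicity, with a stated time of 48 h (a higher number here means a weaker inhibitor, a lower number a stronger inhibitor), compound 1 reaches only the limit of the assay, at > 200000 nM. Compound 2 likewise reaches only a limit in this assay, at > 200000 nM. Compound 3 also gives only a limit, at > 200000 nM. Between compound 2 and compound 1 the change is hydroxy in place of chloro on an aromatic carbon, and the step that the two limits leave unreadable from compound 2 to compound 1 cannot be read, since the limit of > 200000 nM in this assay, at which 3 of the 3 values shown sit, holds all three values. Compound 4 `Nc1nc(O)c2ncn([C@H]3CCCC[C@H]3CO)c2n1` has not yet been measured in this assay. Its change from compound 3 is the same kind of change, (hydroxy in place of chloro on an aromatic carbon), the place differing only in that it is meta to an amino group (1 heavy atom). Compound 4 is therefore expected to sit at a limit as well, which is the step that the limit leaves unreadable from compound 3 to compound 4 that the estimate means, resting on compound 3 at > 200000 nM. The estimated value for compound 4 is 300000 nM, between 100000 nM and 1000000 nM.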

Compound 4, half-maximal inhibitory concentration: > 200000 nM
Compound 4: no number, only a limit (the forecaster's own chance of this, stated with the estimate: 90%); the middle value is on the limit's open side.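

In this assay compound 4, like compound 3, gives only a limit, and no step between the two can be read: the limit of > 200000 nM in this assay, at which 4 of the 4 values shown sit.

The compounds shown leave open whether any compound of this kind would reach a readable value in this assay, and whether hydroxy in place of chloro would then change that value.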